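The source may report more compounds than this note shows. Statements on the series, on what has been measured and on what is new or still open speak of the compounds shown alone.

Measured so far:
- compound 1, `CC(C)C(c1ccc(-c2ccc3cccc(F)c3c2)[nH]c1=O)N1CCN/C1=N\C#N`: 0.632 h
- compound 2, `CC(C)[C@@H](C[C@H]1CCNC1=O)c1ccc(-c2ccc3cccc(F)c3c2)[nH]c1=O`: 0.693 h

Both compounds were tested in an ADME assay on microsomes from liver (Homo sapiens) for metabolic stability; a lower number here means that the compound disappears faster, a higher number that the compound lasts longer. Compound 1 gives the lower of the two numbers, yet compound 2 sits within the usual scatter of it, so the two values cannot be told apart. Compound 3, `CC(C)C(/C=C1/CCNC1=O)c1ccc(-c2ccc3cccc(F)c3c2)[nH]c1=O`, has not yet been measured in this assay. It differs from compound 1 in one place: a group of 7 heavy atoms (5 carbon, 1 nitrogen, 1 oxygen; one five-membered non-aromatic ring with 1 hetero atom) in place of a group of 8 heavy atoms (4 carbon, 4 nitrogen; one five-membered non-aromatic ring with 2 hetero atoms), on a saturated chain carbon bound to an aromatic carbon and a saturated chain carbon. Going by the values given here, no step between measured compounds is known for this change, so the expectation rests only on compound 1 and compound 2, whose values stand close together. The step of a 1.1-fold lower number from compound 1 to compound 3 (0.02 log units; within the scatter) is expected to be small, in no particular direction, and not beyond the scatter. For compound 3 in this assay the expected value is 0.6 h, with a range from 0.3 h to 1.2 h.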

Compound 3, half-life: 0.987 h
For compound 3 the middle estimate is 1.6-fold (0.22 log units) below the measured one; low and high end bracket the measured number.
By their numbers in this assay, from the lowest: compounds 1, 2 and 3 (each within the scatter of the next).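

In this assay, exchanging the group on a saturated chain carbon bound to an aromatic carbon and a saturated chain carbon gives a 1.6-fold higher number from compound 1 to compound 3 (0.19 log units; within the scatter), the first step read at this place. The group with one five-membered non-aromatic ring with 1 hetero atom and 2 double bonds outside aromatic rings can therefore stand in place of the group with 4 nitrogen atoms, a double bond and a triple bond, with no difference that can be told from the scatter. Nothing measured here explains the size of this step.

From the compounds shown here alone, whether a quite different group at this place, such as an amine or a carboxylic acid, would give a step beyond the scatter remains open. So does whether this same exchange would give a similar step on a different core.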